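Moving a methoxy group around the triazole-linked aryl ring

The compounds below may be only part of what the source reports. "The series", "measured", "known", "first", "only" and "open" are said of these compounds alone.

Compounds measured so far:
compound 1 `C#CCOc1ccc(/C=C/C(C)=O)cc1OC`, 65400 nM
compound 2 `COc1cc(/C=C/C(C)=O)ccc1OCc1cn(-c2ccc(/N=N/c3ccccc3)cc2)nn1`, 75900 nM
compound 3 `COc1ccc(-n2cc(COc3ccc(/C=C/C(C)=O)cc3OC)nn2)cc1`, 33700 nM

In a functional assay on MCF7 cells (Homo sapiens) for antiproliferative activity, read by MTT assay, with a stated time of 48 h (on this read-out lower numbers stand for stronger inhibition and higher numbers for weaker inhibition), compound 3 gives the lowest of the three numbers. Compound 1 sits nearest to it, and the gap between compound 3 and compound 1 lies within the scatter, so no order between these two can be claimed. For the measured compounds named here, compound 2 lies furthest from compound 3; the single recorded step, a 2.3-fold lower number from compound 2 to compound 3 (0.35 log units; beyond the scatter), is modest but beyond the scatter.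

Compound 4 `COc1cccc(-n2cc(COc3ccc(/C=C/C(C)=O)cc3OC)nn2)c1` has not yet been measured. It differs from compound 3 only in this: 3-methoxyphenyl in place of 4-methoxyphenyl on an aromatic nitrogen. Going by the values given here, the one measured step concerns a group on an aromatic carbon and exchanges a larger group for a smaller one; it does not speak to a rearrangement of the same atoms on the aryl ring attached to the triazole. Among the compounds with values here, no step in the data bears directly on this change, so the expectation is for no movement beyond the scatter. Compound 4 is therefore expected to give about 35000 nM in this assay, between 15000 nM and 80000 nM, which corresponds to an expected step of a 1.0-fold higher number from compound 3 to compound 4 (0.02 log units; within the scatter).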

Compound 4, half-maximal inhibitory concentration: 1800 nM
Beside the measured number, compound 4's estimate is 19-fold (1.29 log units) above it; measured number below the stated range.
By their numbers in this assay, from the lowest: compound 4; then compounds 3, 1 and 2 (each within the scatter of the next, the first and the last beyond it).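

In this assay, 3-methoxyphenyl in place of 4-methoxyphenyl on the aromatic nitrogen gives a 19-fold lower number from compound 3 to compound 4 (1.27 log units; beyond the scatter), a large step. The two groups have the same atoms and the same counts, so at this place the number answers to how the methoxy group is joined on the ring, even with nothing added or removed. The earlier step, a 2.3-fold lower number from compound 2 to compound 3 (0.35 log units; beyond the scatter), exchanged groups of different size and could not show this. The data hold no measurement that explains the step.

Going by these compounds, with only these compounds, it stays open whether this large step is particular to the methoxy group. Whether an amine or a carboxylic acid in the place of that methoxy group on compound 4, or a longer chain such as ethoxy, would keep so low a number cannot be told from them.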